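Removing the chloro group from compound 2

The compounds below may be only part of what the source reports. "The series", "measured", "known", "first", "only" and "open" are said of these compounds alone.

In a functional assay on L02 cells (Homo sapiens) for inhibition (a lower number here means a stronger inhibitor, a higher number a weaker inhibitor), compound 2 `CCN(C(=O)CC(CC(=O)NCCN1CCCCC1)c1ccc(Cl)cc1)C1Cc2ccccc2C1` gives 84200 nM and stands level with its two measured neighbours. Compound 1 `O=C(CC(CC(=O)NC1Cc2ccccc2C1)c1ccc(Cl)cc1)NCCN1CCCCC1` gives 70400 nM and compound 3 `CCN(C(=O)CC(CC(=O)NCCN1CCCC1)c1ccc(Cl)cc1)C1Cc2ccccc2C1` gives 54200 nM in the same read-out. All three numbers are high for this assay as measured here, and nothing in this small set reaches a much lower range.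

Compound 4 `CCN(C(=O)CC(CC(=O)NCCN1CCCCC1)c1ccccc1)C1Cc2ccccc2C1` differs from compound 2 in one place: hydrogen in place of chloro on an aromatic carbon and in words this is hydrogen in place of chloro on an aromatic carbon, so that 4-chlorophenyl becomes phenyl.

Among the compounds with values here, no measured step covers this change. The nearest evidence is a 1.2-fold higher number from compound 1 to compound 2 (0.08 log units; within the scatter) for ethyl in place of hydrogen on an amide-type nitrogen, and a 1.6-fold lower number from compound 2 to compound 3 (0.19 log units; within the scatter) for pyrrolidin-1-yl in place of piperidin-1-yl. Both lie within the scatter, and both sit away from the aromatic ring. All three measured compounds carry 4-chlorophenyl, so the chloro group itself has not been tested and no direction can be read from the data.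

No step beyond the scatter is therefore expected in this assay here. The expected change is a 1.1-fold higher number from compound 2 to compound 4 (0.03 log units; within the scatter) and it is estimated to stay within the scatter. For compound 4 the estimated value is 90000 nM with an expected range from 48000 nM to 170000 nM in this read-out.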

Compound 4, half-maximal inhibitory concentration: > 100000 nM
Compound 4: only a limit was reported; the forecaster's own chance of this, stated with the estimate: 15%; middle value at least 1.1-fold (0.04 log units) from the limit.
By their numbers in this assay, from the lowest: compounds 3, 1 and 2 (each within the scatter of the next). At a limit, above all of these: compound 4.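

The chloro position now has its first reading: on an aromatic carbon para to a large group, hydrogen in place of chloro gives an at least 1.1-fold higher number from compound 2 to compound 4 (0.07 log units; that floor lies within the scatter) in this assay. Compound 4 is reported only as a limit, so the step has a floor and no measured size: the limit of > 100000 nM in this assay, at which 1 of the 4 values shown sits.

Within the data shown here, the change from 4-chlorophenyl to phenyl therefore brings no lower number in this read-out, which the earlier compounds could not show, as all of them carry the chloro group.

Open, as far as these compounds go, is whether fluoro, methoxy or a carboxylic acid on the same aromatic carbon would give a number well below those of compound 1, compound 2 and compound 3. Also open, from the compounds shown here alone, is whether, with phenyl in place of 4-chlorophenyl, ethyl on the amide-type nitrogen and pyrrolidin-1-yl in place of piperidin-1-yl would give the same small steps seen so far only with the chloro group present.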